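A few compounds are considered here, and "the series" means these few. Any claim that something is new, unique, unknown or untested is made for them only; others in the source may bear on it.

Measured so far in an ADME assay on TZM cells (Homo sapiens) for cytotoxicity, read by MTT assay, with a stated time of 48 h; on this read-out higher numbers stand for lower toxicity in this test and lower numbers for higher toxicity in this test:
- compound 1 `COc1cc(OC)nc(N2C(=O)CSC2c2ccc(C#N)cc2)n1` gives 86500 nM
- compound 2 `Cc1cc(N2C(=O)CSC2c2c(F)cccc2F)nc(C)c1Br` gives 67100 nM
- compound 3 `O=C1CSC(c2c(Cl)cccc2Cl)N1c1ccccn1` gives 149000 nM

Among these three, compound 3 has the highest number. Its gap to compound 2 lies beyond the usual scatter of repeated measurements, so compound 3 is less toxic in this test than compound 2. Its gap to compound 1, on the other hand, lies within that scatter, so no order between compound 3 and compound 1 can be claimed from these numbers.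

The next compound, compound 4 `N#Cc1ccc(N2C(=O)CSC2c2c(Cl)cccc2Cl)nc1`, keeps the shared core of compound 3 and differs from it in a single place: cyano in place of hydrogen on an aromatic carbon. Going by the values given here, none of the measured pairs differ from each other in just one place, so there is no measured step of this kind to lean on. Compound 1 also carries a cyano group and gives 86500 nM, a number within the scatter of compound 3, which gives no reason to expect a large shift.

The step from compound 3 to compound 4 in this assay is therefore expected to be small, perhaps slightly downward, a 1.5-fold lower number from compound 3 to compound 4 (0.17 log units; within the scatter). For compound 4 the estimated value is 100000 nM, with a range from 40000 nM to 250000 nM.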

Compound 4, half-maximal cytotoxic concentration: 60000 nM
The estimate for compound 4 lay 1.7-fold (0.22 log units) above the measured number, and the stated range covers the measured number.
By their numbers in this assay, from the lowest: compounds 4, 2, 1 and 3 (each within the scatter of the next, the first and the last beyond it).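

In this assay, going by these compounds alone, putting cyano on the aromatic carbon of the six-membered ring with one nitrogen, two atoms from the ring nitrogen and para to a large group, gives a 2.5-fold lower number from compound 3 to compound 4 (0.40 log units; beyond the scatter), the first change in a single place that can be read in this set. This shows that the position is not neutral in this test: an addition of only two heavy atoms moves the number beyond the usual scatter, modestly and towards higher toxicity, so compound 4 is more toxic in this test than compound 3. No measurement at hand explains why the number moves.

This single step cannot show whether the shift belongs to cyano itself or would come with almost any group at this carbon, and an amine or a carboxylic acid in the same place would help to separate those two readings. It also leaves open whether cyano would move the number in the same direction and by a similar amount on another carbon of this ring, or on a compound with a different core.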